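A few compounds are considered here, and "the series" means these few. Any claim that something is new, unique, unknown or untested is made for them only; others in the source may bear on it.

Compound 3 `Cn1nc2c(=O)n(CC3(O)CCN(Cc4ccc(-c5ncco5)cc4Cl)CC3)cnc2c1-c1ccc(CN)cc1` is examined in an assay on isolated protein for inhibition of ubiquitin carboxyl-terminal hydrolase 7 (Homo sapiens), with stated times of 30 min and 2 h (on this read-out higher numbers stand for weaker inhibition and lower numbers for stronger inhibition), where it gives 1120 nM and therefore stands highest of the three measured compounds. Its nearest neighbour is compound 2 `Cn1nc2c(=O)n(CC3(O)CCN(Cc4ccc(-c5ccco5)cc4Cl)CC3)cnc2c1-c1ccc(Cl)cc1`, which gives 143 nM, and the furthest is compound 1 `Cn1nc2c(=O)n(CC3(O)CCN(Cc4ccc(-c5ccco5)cc4Cl)CC3)cnc2c1-c1ccc(C2(N)CC2)cc1`, which gives 66.1 nM. Among the measured compounds shown here, the one measured step, a 2.2-fold higher number from compound 1 to compound 2 (0.34 log units; beyond the scatter), concerns chloro in place of 1-aminocyclopropyl on an aromatic carbon of the aryl group carried by the shared core, a different part of the molecule from the one now altered.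

Compound 4 `Cn1nc2c(=O)n(CC3(O)CCN(Cc4ccc(-c5cncs5)cc4Cl)CC3)cnc2c1-c1ccc(CN)cc1` differs from compound 3 only by 1,3-thiazol-5-yl in place of 1,3-oxazol-2-yl on an aromatic carbon. For the measured compounds named here, no measured step touches this five-membered ring, so no measured step bears directly on the change; compounds 1 and 2 both carry furan-2-yl at this place, but each also differs from compound 3 elsewhere, so they give no clean comparison. A step no larger than the usual scatter is therefore expected, in either direction, meaning a 1.2-fold lower number from compound 3 to compound 4 (0.09 log units; within the scatter). For compound 4 the expected value in this assay is 900 nM, with a range from 350 nM to 2500 nM.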

Compound 4, half-maximal inhibitory concentration: 117 nM
Compound 4: the middle estimate sits 7.7-fold (0.89 log units) above what was measured, and the stated range ends above it.
By their numbers in this assay, from the lowest: compounds 1, 4 and 2 (each within the scatter of the next, the first and the last beyond it); then compound 3.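

In this assay, 1,3-thiazol-5-yl in place of 1,3-oxazol-2-yl gives a 9.6-fold lower number from compound 3 to compound 4 (0.98 log units; beyond the scatter) and so shows that the number responds strongly to the five-membered ring on the aromatic carbon para to a large group. Among the compounds shown here, the earlier compounds could not show this, as their one measured step lay on the aryl group carried by the shared core. The response arises even though the two rings match in heavy-atom count, hydrogen-bond donors and acceptors, and net charge, and nothing measured here explains it.

The change swaps oxygen for sulfur and also moves the point of attachment, so the compounds shown cannot separate these two differences. On these data alone, a 1,3-thiazol-2-yl or 1,3-oxazol-5-yl group at this place would pull them apart, and whether the step holds with other groups on the aryl ring remains open.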